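Notes on chain-terminus changes in the series

The source may report more compounds than this note shows. Statements on the series, on what has been measured and on what is new or still open speak of the compounds shown alone.

Measured so far:
compound 1 `CCOc1ccc2c(=O)c(-c3ccc(O)cc3)coc2c1`: 80 nM
compound 2 `CCOC(=O)CCCCOc1ccc2c(=O)c(-c3ccc(O)cc3)coc2c1`: 240 nM
compound 3 `NCCCCOc1ccc2c(=O)c(-c3ccc(O)cc3)coc2c1`: 250 nM

In an assay (Cricetulus griseus) for inhibition of aldehyde dehydrogenase, mitochondrial (Homo sapiens) (on this read-out higher numbers stand for weaker inhibition and lower numbers for stronger inhibition), compound 3 gives the highest of the three numbers. The step of a 3.1-fold higher number from compound 1 to compound 3 (0.49 log units; beyond the scatter) lies beyond the scatter, whereas a 1.0-fold higher number from compound 2 to compound 3 (0.02 log units; within the scatter) lies within it, so the chain extension itself costs a modest step and the group at its end hardly registers.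

Compound 4 `C=CCCCCOc1ccc2c(=O)c(-c3ccc(O)cc3)coc2c1` differs from compound 3 by vinyl in place of amino on a saturated chain carbon, four bonds along the chain from an oxygen on an aromatic ring. Among the measured compounds shown here, the one step at this same place, a 1.0-fold higher number from compound 2 to compound 3 (0.02 log units; within the scatter), was flat; a 3.0-fold higher number from compound 1 to compound 2 (0.48 log units; beyond the scatter) and a 3.1-fold higher number from compound 1 to compound 3 (0.49 log units; beyond the scatter) concern chain attachment, not the terminus. A terminal swap is therefore expected to give a 1.1-fold lower number from compound 3 to compound 4 (0.04 log units; within the scatter), no step beyond the scatter. Compound 4 is estimated at 230 nM, range 110 nM to 500 nM.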

Compound 4, half-maximal inhibitory concentration: 150 nM
The estimate for compound 4 lay 1.5-fold (0.19 log units) above the measured number; measured number inside the range.
By their numbers in this assay, from the lowest: compounds 1, 4, 2 and 3 (each within the scatter of the next, the first and the last beyond it).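

In this assay the chain end now covers three groups with no step beyond the scatter, as a 1.7-fold lower number from compound 3 to compound 4 (0.22 log units; within the scatter) and a 1.6-fold lower number from compound 2 to compound 4 (0.20 log units; within the scatter) both stay within it. Attachment of the chain also reads differently with vinyl at its end: a 1.9-fold higher number from compound 1 to compound 4 (0.27 log units; within the scatter) stays within the scatter, whereas the steps from compound 1 to compound 2 and compound 3 lie beyond it. No evidence bears on the origin of these differences.

As far as these compounds go, whether a carboxylic acid or a phenyl ring at the chain end would give a step beyond the scatter remains open. So does the effect of a longer chain.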